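The source may report more compounds than this note shows. Statements on the series, on what has been measured and on what is new or still open speak of the compounds shown alone.

Measured so far:
Compound 1 `CC1=NC(C)=C(C(=O)O)C(c2ccc([N+](=O)[O-])cc2)/C1=C(\O)OC/C=C/c1ccccc1` gives 1600 nM in a functional assay on thoracic aorta for inhibition of Voltage-gated L-type calcium channel (Rattus norvegicus); a higher number here means a weaker inhibitor, a lower number a stronger inhibitor.
Compound 2 `CC1=NC(C)=C(C(=O)O)C(c2cccc(C(=O)O)c2)/C1=C(\O)OC/C=C/c1ccccc1` reaches only the assay limit of > 10000 nM in this assay.
Compound 3 `CC1=NC(C)=C(C(=O)O)C(c2cccc(I)c2)/C1=C(\O)OC/C=C/c1ccccc1` gives 13 nM in this assay.

Among the two numbers that were actually reached, compound 1 stands highest; the nearest is compound 3, with a 120-fold lower number from compound 1 to compound 3 (2.09 log units; beyond the scatter). Compound 2 sits at the limit, (the limit of > 10000 nM in this assay, at which 1 of the 3 values shown sits), so its exact number is not known.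

The unmeasured compound 4 `CC1=NC(C)=C(C(=O)O)C(c2cccnc2)/C1=C(\O)OC/C=C/c1ccccc1` differs from compound 1 in one place: pyridin-3-yl in place of 4-nitrophenyl on a saturated ring carbon. Going by the values given here, no measured step introduces a pyridin-3-yl group, so none bears on this change directly. What the measured steps do show is that the group on this saturated ring carbon can move the number very far: a 120-fold lower number from compound 1 to compound 3 (2.09 log units; beyond the scatter) is large and downward, while an at least 6.2-fold higher number from compound 1 to compound 2 (0.79 log units; beyond the scatter) is at least modest and upward. The aromatic group that enters in compound 4 is a carbon-only ring replaced by one with a hetero atom, without a substituent of the kind that set compound 3 apart; a somewhat weaker inhibitor than compound 1 is therefore expected, with a 1.9-fold higher number from compound 1 to compound 4 (0.27 log units; within the scatter) as the expected step. For compound 4 the estimate in this assay is 3000 nM, expected to fall between 700 nM and 12000 nM.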

Compound 4, half-maximal inhibitory concentration: 190 nM
Compound 4: middle estimate off by 16-fold (1.20 log units), on the high side; the measured number lies below the stated range.
By their numbers in this assay, from the lowest: compound 3; then compound 4; then compound 1. At a limit, above all of these: compound 2.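

In this assay, pyridin-3-yl in place of 4-nitrophenyl gives an 8.4-fold lower number from compound 1 to compound 4 (0.93 log units; beyond the scatter), so at this saturated ring carbon an aromatic ring with one hetero atom and no substituent already improves on the 4-nitrophenyl group. A substituent is therefore not needed to improve on the 4-nitrophenyl group, yet 3-iodophenyl stays ahead of pyridin-3-yl, with a 15-fold higher number from compound 3 to compound 4 (1.16 log units; beyond the scatter). Compound 2 gives no exact number, so the gap between 3-carboxyphenyl and pyridin-3-yl, an at least 52-fold lower number from compound 2 to compound 4 (1.72 log units; beyond the scatter), is only a bound set by a limit: the limit of > 10000 nM in this assay, at which 1 of the 4 values shown sits.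

Still open, on these data alone, is how pyridin-2-yl or pyridin-4-yl would compare with pyridin-3-yl, and whether a plain phenyl group would sit nearer compound 1 or compound 4, a comparison that would separate the effect of the ring nitrogen from the loss of the nitro group. Also open, as far as these compounds go, is whether an iodo group, a chloro group or an amine on the pyridin-3-yl ring would bring the number closer to that of compound 3.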